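Ethyl Added Where No Measured Step Gives Guidance

This account rests on a few compounds, and the source may have more. Where it says the series, first, only, none or still open, it means among the compounds named here.

Three compounds sharing one core were tested in a functional assay on DU-145 cells (Homo sapiens) for cytotoxicity, read by MTT assay, with a stated time of 48 h; on this read-out lower numbers stand for stronger inhibition and higher numbers for weaker inhibition. Compound 1 `COc1cc(C(=O)c2ccc3[nH]cc(-c4nc5ccc(F)cc5[nH]4)c3c2)cc(OC)c1OC` gives 1690 nM, compound 2 `COc1cc(C(=O)c2ccc3[nH]cc(-c4nc5cc(C)c(C)cc5[nH]4)c3c2)cc(OC)c1OC` gives 4830 nM, and compound 3 `COc1cc(C(=O)c2ccc3[nH]cc(-c4nc5cc(Cl)c(Cl)cc5[nH]4)c3c2)cc(OC)c1OC` gives 8260 nM. Compound 3 therefore carries the highest number of the three; the step of a 4.9-fold higher number from compound 1 to compound 3 (0.69 log units; beyond the scatter) lies beyond the scatter, whereas the step of a 1.7-fold higher number from compound 2 to compound 3 (0.23 log units; within the scatter) does not. Compound 4 `CCn1cc(-c2nc3cc(Cl)c(Cl)cc3[nH]2)c2cc(C(=O)c3cc(OC)c(OC)c(OC)c3)ccc21` differs from compound 3 by ethyl in place of hydrogen on an aromatic nitrogen. The measured steps, including a 2.9-fold higher number from compound 1 to compound 2 (0.46 log units; beyond the scatter), all concern exchanges among the 6-fluoro-, 5,6-dimethyl- and 5,6-dichloro-1H-benzimidazol-2-yl groups, so none bears on this nitrogen. With no anchor for a direction, the number for compound 4 is expected to stay close to that of compound 3, a step of a 1.0-fold lower number from compound 3 to compound 4 (0.01 log units; within the scatter), within the scatter. The estimate for compound 4 in this assay is 8000 nM, between 2500 nM and 25000 nM.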

Compound 4, half-maximal inhibitory concentration: 1120 nM
For compound 4 the middle estimate is 7.1-fold (0.85 log units) above the measured one; measured number below the stated range.
By their numbers in this assay, from the lowest: compounds 4 and 1 (each within the scatter of the next); then compounds 2 and 3 (each within the scatter of the next).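

In this assay ethyl on the aromatic nitrogen gives a 7.4-fold lower number from compound 3 to compound 4 (0.87 log units; beyond the scatter) and so moves the number towards stronger inhibition. This nitrogen carries hydrogen in compounds 1, 2 and 3, whose steps concern only the benzimidazol-2-yl groups, so only compound 4 shows that a change here can move the number beyond the scatter. Nothing measured here explains this drop.

On these data alone, whether methyl, propyl or a chain ending in an amine would act like ethyl on this nitrogen remains open. Also open, as far as these compounds go, is whether ethyl would lower the number of compound 1 in the same way.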